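The source may hold more compounds than are shown below. What is called first, only, known or untested is meant among the compounds shown, and "the series" means these compounds.

Compound 1 `CCC1Oc2ccc(Cl)cc2N(O)C1=O` — 1600 nM in a functional assay on the whole organism for inhibition, with Allium cepa as the target, with a stated time of 7 days; on this read-out lower numbers stand for stronger inhibition and higher numbers for weaker inhibition
Compound 2 `CCCCC(=O)ON1C(=O)COc2ccc(Cl)cc21` — 200 nM in this assay
Compound 3 `CCCON1C(=O)COc2ccc(Cl)cc21` — 200 nM in this assay

Compound 1 gives the highest number of the three. Compound 2 and compound 3 each sit at a lower number, a gap that lies beyond the scatter, so compound 1 is the weakest inhibitor among the measured compounds. Among the compounds with values here, the only step between measured compounds, no change at the digits printed from compound 2 to compound 3 (within the scatter), concerns the group on the ring nitrogen's oxygen and stays within the scatter; it tells nothing about the aromatic halogen.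

Compound 4 `CCC1Oc2ccc(F)cc2N(O)C1=O` differs from compound 1 in one place: fluoro in place of chloro on an aromatic carbon. No measured pair in this series touches that position, so the step from compound 1 to compound 4 rests on no shown comparison, and the expectation is that the number stays close to that of compound 1, without a change beyond the scatter: a 1.3-fold higher number from compound 1 to compound 4 (0.10 log units; within the scatter). For compound 4 the estimated half-maximal inhibitory concentration is 2000 nM, with a range from 700 nM to 6000 nM.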

Compound 4, half-maximal inhibitory concentration: 1300 nM
For compound 4 the middle estimate is 1.5-fold (0.19 log units) above the measured one; the range from low to high includes it.
By their numbers in this assay, from the lowest: compounds 2 and 3 (each within the scatter of the next); then compounds 4 and 1 (each within the scatter of the next).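

Within the data shown here, the change from chloro to fluoro gives the first reading at this aromatic carbon, since compounds 1, 2 and 3 all carry chloro there. In this assay, the swap gives a 1.2-fold lower number from compound 1 to compound 4 (0.09 log units; within the scatter), so this assay does not separate these two halogens on the core of compound 1. Among these compounds, the result covers only this one exchange, on a core with a free hydroxy group on the ring nitrogen. No measured evidence on the properties of these compounds bears on this result. The compounds shown leave open how a bromo, methyl or methoxy group, or hydrogen alone, would read at this aromatic carbon. They also leave open whether fluoro would read the same alongside the butylcarbonyl or propyl group on the oxygen of compounds 2 and 3.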